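Extending the propoxy chain on the biaryl with a methylsulfonyl cap

A few compounds are considered here, and "the series" means these few. Any claim that something is new, unique, unknown or untested is made for them only; others in the source may bear on it.

Measured compounds: compound 1 `Cc1cccc(C)c1-c1cccc(COc2ccc(SCC(=O)O)cc2)c1` with 195 nM; compound 2 `Cc1cccc(C)c1-c1cccc(COc2ccc(S(=O)(=O)CC(=O)O)cc2)c1` with 66.1 nM; compound 3 `CCCOc1cc(C)c(-c2cccc(COc3ccc(S(=O)(=O)CC(=O)O)cc3)c2)c(C)c1` with 69.2 nM.

All three were tested in a functional assay on CHO cells for agonist activity at Free fatty acid receptor 1 (Homo sapiens), read by FLIPR and calcium flux; a lower number here means that less compound is needed, a higher number that more compound is needed for the effect. Compound 2 gives the lowest number of the three; its nearest neighbour is compound 3, which lies within the usual scatter of it, so the two cannot be ranked, while compound 1 stands apart by a 3.0-fold lower number from compound 1 to compound 2 (0.47 log units; beyond the scatter). Compound 4 `Cc1cc(OCCCS(C)(=O)=O)cc(C)c1-c1cccc(COc2ccc(S(=O)(=O)CC(=O)O)cc2)c1` has not yet been measured. It differs from compound 2 in one place: 3-(methylsulfonyl)propoxy in place of hydrogen on an aromatic carbon.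

Among the compounds with values here, the only measured step that bears on this change is the one from compound 2 to compound 3, where a propoxy group entered at the same aromatic carbon and gave a 1.0-fold higher number from compound 2 to compound 3 (0.02 log units; within the scatter). Compound 4 carries a longer chain at that carbon, ending in a methylsulfonyl group, for which no comparison exists among the measured compounds. Because the step of a 1.0-fold higher number from compound 2 to compound 3 (0.02 log units; within the scatter) stayed within the scatter, compound 4 is expected to give a number in this assay close to that of compound 2, that is a 1.1-fold higher number from compound 2 to compound 4 (0.02 log units; within the scatter). The estimate for compound 4 is 70 nM, with a range from 30 nM to 170 nM.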

Compound 4, half-maximal effective concentration: 170 nM
For compound 4 the middle estimate is 2.4-fold (0.39 log units) below the measured one; the measured number falls inside the stated range.
By their numbers in this assay, from the lowest: compounds 2 and 3 (each within the scatter of the next); then compounds 4 and 1 (each within the scatter of the next).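

At the aromatic carbon para to a large group and meta to two methyl groups, the propoxy step had left the number in this assay within the scatter, but the same carbon does not accept every chain equally, as 3-(methylsulfonyl)propoxy in place of hydrogen gives a modest rise (a 2.6-fold higher number from compound 2 to compound 4 (0.41 log units; beyond the scatter)). Compound 3 makes the closer comparison, and placing methylsulfonyl on the saturated chain carbon three bonds along from the oxygen on the aromatic ring gives a rise of similar size (a 2.5-fold higher number from compound 3 to compound 4 (0.39 log units; beyond the scatter)), so the change tracks the methylsulfonyl group at the chain end and not the propoxy chain alone. Nothing measured here accounts for this rise.

The compounds shown leave open whether a hydroxyl, an amine or a carboxylic acid at the end of the propoxy chain would raise the number as methylsulfonyl does, or leave it where propoxy left it. Also open, going by these compounds, is how a shorter or longer chain ending in methylsulfonyl would read at this carbon, and whether the step depends on the length of the chain at all.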